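Hydroxy to amino: working notes on compound 3

A few compounds are considered here, and "the series" means these few. Any claim that something is new, unique, unknown or untested is made for them only; others in the source may bear on it.

compound 1 `CCNCC(=O)Nc1cc(OC)ccc1C(=O)c1ccc(OC)c2c1OC(C)(C)C=C2` at 2690 nM
compound 2 `C=C(c1ccc(OC)cc1NC(=O)CO)c1ccc(OC)c2c1C=CC(C)(C)O2` at 100 nM

Both numbers come from a functional assay on HeLa cells (Homo sapiens) for antiproliferative activity, read by MTT assay, with a stated time of 48 h (a lower number here means a stronger inhibitor, a higher number a weaker inhibitor), and compound 2 holds the lower one, with compound 1 above it by a gap beyond the usual scatter. The two differ in more than one place, so that gap measures no single change. Compound 3 `C=C(c1ccc(OC)cc1NC(=O)CN)c1ccc(OC)c2c1C=CC(C)(C)O2` is compound 2 with one change, amino in place of hydroxy on a saturated chain carbon bound to a carbonyl carbon. Among the compounds with values here, no measured step covers that change, so the expectation rests only on compound 2 at 100 nM as the starting point. In this assay a slightly higher number is expected, of a size about within the scatter. The estimated step is a 1.6-fold higher number from compound 2 to compound 3 (0.20 log units; within the scatter) in that direction. For compound 3 the expected value is 160 nM within an estimated range of 40 nM to 600 nM for repeat measurements.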

Compound 3, half-maximal inhibitory concentration: 200 nM
Estimate against measurement, compound 3: 1.3-fold (0.10 log units) below; the measured number falls inside the stated range.
By their numbers in this assay, from the lowest: compounds 2 and 3 (each within the scatter of the next); then compound 1.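

In this assay, within the data shown here, the first single-place comparison reads a 2.0-fold higher number from compound 2 to compound 3 (0.30 log units; within the scatter) and so gives no separation between hydroxy and amino on this saturated chain carbon bound to a carbonyl carbon. As far as these two compounds go, the position accepts either group without a change in the number that can be told from scatter, a reading that compound 1 could not supply, as it differs from both in more than one place. Nothing measured here offers a reason for this result.

On these data alone, it remains open whether the same holds for other groups on this carbon, such as a dimethylamino group, a carboxylic acid or a longer chain. As far as these compounds go, whether hydroxy and amino also read alike on the core of compound 1 stays open as well.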